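The source may hold more compounds than are shown below. What is called first, only, known or untested is meant among the compounds shown, and "the series" means these compounds.

Among the compounds with values here, compound 2 `O=C(CCc1ccc(C(F)(F)F)cc1)Nc1ccc2nc(N3CCCCCC3)ccc2c1` gives the highest number of the two values measured so far in an assay on isolated protein for displacement of a labelled ligand from melanin-concentrating hormone receptor 1 (Homo sapiens) (a lower number here means a stronger inhibitor, a higher number a weaker inhibitor), namely 36 nM; its nearest neighbour, compound 1 `O=C(CCc1ccc(C(F)(F)F)cc1)Nc1ccc2nc(N3CC4CCC3CC4)ccc2c1`, gives 3 nM in this assay. Within the data shown here, the one step known within this pair is a 12-fold higher number from compound 1 to compound 2 (1.08 log units; beyond the scatter), which exchanged one saturated amine for another on the same aromatic carbon of the shared core. Compound 3 `CNC(=O)NC1CCN(c2ccc3cc(NC(=O)CCc4ccc(C(F)(F)F)cc4)ccc3n2)C1` carries 3-((methylcarbamoyl)amino)pyrrolidin-1-yl in place of azepan-1-yl on an aromatic carbon. Among the measured compounds shown here, the only step that bears on this change is the large amine swap from compound 1 to compound 2, and it shows that this position responds strongly to the shape of the attached ring, but it does not tell in which direction a urea-bearing five-membered ring will move the number. The step is therefore expected to be a 1.2-fold lower number from compound 2 to compound 3 (0.08 log units; within the scatter), with wide uncertainty in either direction. Compound 3 is estimated at 30 nM, within a range of 5 nM to 200 nM.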

Compound 3, half-maximal inhibitory concentration: 6 nM
Beside the measured number, compound 3's estimate is 5.0-fold (0.70 log units) above it; measured number inside the range.
By their numbers in this assay, from the lowest: compounds 1 and 3 (each within the scatter of the next); then compound 2.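

In this assay, within the data shown here, the exchange of azepan-1-yl for 3-((methylcarbamoyl)amino)pyrrolidin-1-yl gives a 6.0-fold lower number from compound 2 to compound 3 (0.78 log units; beyond the scatter) and so shows that this position can accept a five-membered ring carrying a urea side chain, a kind of group the earlier compounds did not include. Against the bridged amine, the same group gives a 2.0-fold higher number from compound 1 to compound 3 (0.30 log units; within the scatter) and this assay does not separate the two, although the groups differ in ring size and in heavy atoms.

On these data alone, how an unsubstituted pyrrolidin-1-yl or a 3-aminopyrrolidin-1-yl would read at this position stays open, so the shares of the ring and of the urea cannot be told apart. Also open, as far as these compounds go, is whether the methyl on the urea could give way to a longer chain, or the urea to a plain acetamide. Nothing measured here explains these differences.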